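Swapping the Side Chain of Compound 3 for a Benzyl Group

The source may report more compounds than this note shows. Statements on the series, on what has been measured and on what is new or still open speak of the compounds shown alone.

Three compounds have been measured in a functional assay on MDA-MB-231 cells (Homo sapiens) for cytotoxicity, read by MTT assay, with a stated time of 72 h, tested at 5 uM, in the absence of a further agent; a higher number here means a weaker effect of the compound at the concentration tested, a lower number a stronger effect:

compound 1 `CC1(C)CC(N)=Nc2ccc(Cl)cc21` gives 81%
compound 2 `CCCNC1=Nc2ccc(Cl)cc2C(C)(C)C1` gives 82.4%
compound 3 `CN(C)CCCNC1=Nc2ccc(Cl)cc2C(C)(C)C1` gives 38%

Compound 3 stands lowest of the three, and both of its steps to the other two lie beyond the scatter: a number 43 percentage points lower from compound 1 to compound 3 (beyond the scatter) and a number 44.4 percentage points lower from compound 2 to compound 3 (beyond the scatter). In contrast, a number 1.4 percentage points higher from compound 1 to compound 2 (within the scatter) shows that adding a plain propyl chain on the amine nitrogen changed little.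

Compound 4 `CC1(C)CC(NCc2ccccc2)=Nc2ccc(Cl)cc21` differs from compound 3 by phenyl in place of 2-(dimethylamino)ethyl on a saturated chain carbon bound to an amine nitrogen. The step that bears most on this is a number 44.4 percentage points lower from compound 2 to compound 3 (beyond the scatter), which shows that the dimethylamino group on the chain is what set compound 3 apart; compound 4 no longer carries it. The step of a number 1.4 percentage points higher from compound 1 to compound 2 (within the scatter) shows that a simple carbon substituent on the nitrogen leaves the number near that of compound 1. A phenyl on the chain is new here, so a return toward the numbers of compounds 1 and 2 is expected, but with uncertainty.

Compound 4 is therefore estimated at 65%, within 35% to 90%, meaning an expected step of a number 27 percentage points higher from compound 3 to compound 4 (beyond the scatter).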

Compound 4, a percentage reported as activity, at one concentration (the size of the read-out at that concentration, not a potency): 68.1%
The estimate for compound 4 lay 3.1 percentage points below the measured number, and the stated range covers the measured number.
By their numbers in this assay, from the lowest: compound 3; then compound 4; then compounds 1 and 2 (each within the scatter of the next).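

In this assay a ring on this chain does what a plain propyl chain did not: benzyl on the amine nitrogen gives a step of a number 12.9 percentage points lower from compound 1 to compound 4 (beyond the scatter) and, against the propyl compound, a step of a number 14.3 percentage points lower from compound 2 to compound 4 (beyond the scatter) so a substituent without a dimethylamino group can still lower the number. The dimethylamino chain nevertheless keeps a clear lead over benzyl, with a number 30.1 percentage points higher from compound 3 to compound 4 (beyond the scatter) and so compound 3 still gives the lowest number of the four. No measurement shown here accounts for the effect of either group.

Open, on these data alone, is whether another amine, such as pyrrolidine or morpholine, at the end of the propyl chain would match dimethylamino. Also open, as far as these compounds go, is whether a phenethyl group, which holds the phenyl ring further out, would lower the number beyond that of benzyl.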